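The source may hold more compounds than are shown below. What is called first, only, known or untested is meant among the compounds shown, and "the series" means these compounds.

Compound 1, `C=C1C[C@]23C[C@@]1(O)CC[C@H]2c1ccc(OS(=O)(=O)c2ccc(C)cc2)c(C)c1[C@@H]3Cn1cc(-c2ccc(Cl)cc2)nn1`, was examined in a functional assay on A549 cells (Homo sapiens) for cytotoxicity, read by MTT assay, with a stated time of 4 days (on this read-out lower numbers stand for stronger inhibition and higher numbers for weaker inhibition), where compound 1 gives > 20000 nM, which is a limit of the assay and not a number. For compound 1 this is the limit of > 20000 nM in this assay, at which 1 of the 2 values shown sits. Within the data shown here, compound 2, `C=C1C(=O)[C@]23C[C@@]1(O)CC[C@H]2c1ccc(OS(=O)(=O)c2ccc(C)cc2)c(C)c1[C@@H]3Cn1cc(-c2ccccn2)nn1`, differs from compound 1 in more than one place, and in this assay compound 2 gives 2310 nM, the only number among the two values. Compound 3, `C=C1C[C@]23C[C@@]1(O)CC[C@H]2c1ccc(OS(=O)(=O)c2ccc(C)cc2)c(C)c1[C@@H]3Cn1cc(-c2ccc(F)cc2)nn1`, has not yet been measured. It differs from compound 1 by fluoro in place of chloro on an aromatic carbon. Among the measured compounds shown here, since compound 1 stands at the limit, no measured step shows how large such a change is here. The step that the limit leaves unreadable from compound 1 to compound 3 is expected to be none beyond the scatter. Compound 3 is therefore estimated to stay near the limit, at about 30000 nM, with a range from 10000 nM to 100000 nM.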

Compound 3, half-maximal inhibitory concentration: > 20000 nM
Compound 3: a limit, no number (the forecaster's own chance of this, stated with the estimate: 75%); the middle value does not contradict the limit.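

No step from compound 1 to compound 3 can be read, because both compounds give a limit of the assay and not a number: the limit of > 20000 nM in this assay, at which 2 of the 3 values shown sit.

The compounds shown leave open whether fluoro in place of chloro on an aromatic carbon makes any difference in this assay.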